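Benzyl in place of imidazolylmethyl on the shared core

This account rests on a few compounds, and the source may have more. Where it says the series, first, only, none or still open, it means among the compounds named here.

Among the compounds with values here, in an assay on CHO cells for displacement of a labelled ligand from prostaglandin E2 receptor EP4 subtype (Mus musculus), read by scintillation counting (on this read-out lower numbers stand for stronger inhibition and higher numbers for weaker inhibition), compound 2 `O=C(O)/C=C/c1ccc(Cn2ccnc2)cc1OCCc1ccc2ccccc2c1` gives 2200 nM, the higher of the two numbers so far; compound 1 `O=C(O)/C=C/c1ccc(Cn2cccn2)cc1OCCc1ccc2ccccc2c1` gives 670 nM. Within the data shown here, the single measured step at this position, a 3.3-fold higher number from compound 1 to compound 2 (0.52 log units; beyond the scatter), shows that the azole identity on this chain carbon matters modestly. Compound 3 `O=C(O)/C=C/c1ccc(Cc2ccccc2)cc1OCCc1ccc2ccccc2c1` carries phenyl in place of 1H-imidazol-1-yl on a saturated chain carbon bound to an aromatic carbon. Among the measured compounds shown here, no measured pair covers an azole to phenyl exchange, so direction rests on compound 1 being the lower number. Compound 3 is expected to move back toward that number, an estimated 2.4-fold lower number from compound 2 to compound 3 (0.39 log units; beyond the scatter), giving an expected 900 nM within 250 nM to 3500 nM.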

Compound 3, inhibition constant: 2100 nM
Estimate against measurement, compound 3: 2.3-fold (0.37 log units) below; measured number inside the range.
By their numbers in this assay, from the lowest: compound 1; then compounds 3 and 2 (each within the scatter of the next).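

In this assay the phenyl of compound 3 and the 1H-imidazol-1-yl of compound 2 read alike, with a 1.0-fold lower number from compound 2 to compound 3 (0.02 log units; within the scatter) at this saturated chain carbon. The 1H-pyrazol-1-yl of compound 1 stands apart from the phenyl too, with a 3.1-fold higher number from compound 1 to compound 3 (0.50 log units; beyond the scatter) on the same carbon. An azole at this place therefore does not by itself separate a compound from the carbon-only ring: one azole reads like phenyl and the other does not.

Still open, from the compounds shown here alone, is how a 1H-1,2,3-triazol-1-yl, a morpholine or a cyclohexyl group would read on this carbon. Nothing at hand speaks to the reason behind these numbers.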